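From Benzyl to Hydrogen on Compound 1

A few compounds are considered here, and "the series" means these few. Any claim that something is new, unique, unknown or untested is made for them only; others in the source may bear on it.

In a functional assay on WiDr cells (Homo sapiens) for antiproliferative activity, read by sulforhodamine B assay, with a stated time of 48 h (on this read-out lower numbers stand for stronger inhibition of growth and higher numbers for weaker inhibition of growth), compound 1 (`CC(C)(C)[Si](C)(C)O[C@@H]1CCCO[C@@H]1/C=C/C(=O)OCc1ccccc1`) gives 90000 nM as its measured value. Compound 3 (`COC(=O)/C=C/[C@H]1OCCC[C@@H]1O[Si](C)(C)C(C)(C)C`) gives 84000 nM and so stands level with compound 1 within the scatter. Compound 2 (`O=C(/C=C/[C@H]1OCCC[C@H]1O)OCc1ccccc1`) gives > 100000 nM which is a limit and not a number. All three inhibit growth only weakly, and the limit of > 100000 nM in this assay, at which 1 of the 3 values shown sits, leaves little room to read any further loss as a number.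

Compound 4 (`CC(C)(C)[Si](C)(C)O[C@@H]1CCCO[C@@H]1/C=C/C(=O)O`) differs from compound 1 by hydrogen in place of benzyl on an oxygen next to a carbonyl group and in words this is hydrogen in place of benzyl on an oxygen next to a carbonyl group. Among the measured compounds shown here, no measured step touches that place. For the measured compounds named here, the only measured step, an at least 1.1-fold higher number from compound 1 to compound 2 (0.04 log units; that floor lies within the scatter), lies elsewhere on the core and gives an indirect guide at best. No step beyond the scatter is therefore expected in this assay although a bare limit is quite possible. The estimated change is no change at the digits printed from compound 1 to compound 4 (within the scatter) on the expected reading. For compound 4 the expected value is 90000 nM with an estimated range from 40000 nM to 200000 nM for the measurement.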

Compound 4, concentration for 50% growth inhibition: > 100000 nM
Compound 4: a limit, no number; the forecaster's own chance of this, stated with the estimate: 50%; at least 1.1-fold (0.04 log units) between middle value and limit.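

Among the compounds shown here, at the oxygen next to a carbonyl group, a place the earlier steps did not touch, hydrogen in place of benzyl gives in this assay an at least 1.1-fold higher number from compound 1 to compound 4 (0.04 log units; that floor lies within the scatter), so this change brings no gain in growth inhibition. Compound 4 gives > 100000 nM, which is a limit and not a number. The true size of this step therefore cannot be read, and more of the series now sits at the edge of what the read-out can show: the limit of > 100000 nM in this assay, at which 2 of the 4 values shown sit.

The compounds shown leave open what a longer chain such as phenethyl, or a benzyl amide with nitrogen in place of this oxygen, would do to growth inhibition. They also leave open whether any change at this place can move these weak values into a clearly stronger range.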